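Buffer stability notes: from compound 2 to compound 3

The source may hold more compounds than are shown below. What is called first, only, known or untested is meant among the compounds shown, and "the series" means these compounds.

Compound 1 `C=CS(=O)(=O)c1cc(C(F)(F)F)cc(C(F)(F)F)c1` and compound 2 `FC(F)(F)c1cc(C2CO2)cc(C(F)(F)F)c1` share the same core. In an ADME assay for pharmacokinetics, read by HPLC, in phosphate buffer, with a stated time of 72 h, at pH 7.4, tested at 250 uM (a lower number here means that the compound disappears faster, a higher number that the compound lasts longer), compound 1 gives < 0.017 h, which is a limit of the assay (the limit of < 0.017 h in this assay, at which 1 of the 2 values shown sits). In this assay compound 2 gives > 50 h, also a limit (the limit of > 50 h in this assay, at which 1 of the 2 values shown sits). The step of an at least 2900-fold higher number from compound 1 to compound 2 (3.46 log units; beyond the scatter) is known only as a lower bound on its size. Compound 2 stands at the upper end of the numbers shown, with no measured number beyond it. Compound 3 `Fc1cc(C(F)(F)F)cc(C(F)(F)F)c1` differs from compound 2 by fluoro in place of oxiran-2-yl on an aromatic carbon. Among the compounds with values here, the single measured step, an at least 2900-fold higher number from compound 1 to compound 2 (3.46 log units; beyond the scatter), concerns the exchange of vinylsulfonyl for oxiran-2-yl and involves no fluoro; no step shows what removing oxiran-2-yl does on its own. With compound 2 already at a limit, the expected step that the limit leaves unreadable from compound 2 to compound 3 is that the number stays at or beyond that limit. Compound 3 is expected to give 60 h, with a range of 20 h to 200 h, in this assay most probably reported again only as a limit.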

Compound 3, half-life: > 50 h
Compound 3: no number, only a limit; the forecaster's own chance of this, stated with the estimate: 85%; the middle value is on the limit's open side.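

In this assay compound 3 gives > 50 h, which is a limit and not a number, so oxiran-2-yl is not required at this position for a result at that limit. Fluoro in place of vinylsulfonyl on an aromatic carbon gives an at least 2900-fold higher number from compound 1 to compound 3 (3.46 log units; beyond the scatter), so the large step first seen with oxiran-2-yl recurs with a group that has no ring. The step between compound 2 and compound 3 cannot be read: the limit of > 50 h in this assay, at which 2 of the 3 values shown sit.

Any real difference between oxiran-2-yl and fluoro in this assay remains open, as neither compound has a measured number. Also open, on these data alone, is whether the short half-life of compound 1 goes with the vinyl part or the sulfonyl part, which a methylsulfonyl group on the same carbon would separate, and whether an amine at this position would give a number inside the limits.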